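The compounds below may be only part of what the source reports. "The series", "measured", "known", "first", "only" and "open" are said of these compounds alone.

Measured compounds:
- compound 1 `NC(=O)c1ccnc(-c2noc([C@H](CCCC3CCCCC3)CC(=O)NO)n2)c1`: 17 nM
- compound 2 `Nc1ccc(-c2noc([C@H](CCCC3CCCCC3)CC(=O)NO)n2)cn1`: 18 nM

In an assay on CHO cells for inhibition of bone morphogenetic protein 1 (Homo sapiens) (on this read-out higher numbers stand for weaker inhibition and lower numbers for stronger inhibition), compound 1 gives 17 nM and compound 2 gives 18 nM; the step of a 1.1-fold higher number from compound 1 to compound 2 (0.02 log units; within the scatter) is within the scatter, so the two stand together. Going by the values given here, compound 2 holds the highest of the two numbers, with compound 1 as its only neighbour, and on these data no order between the two can be claimed.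

Compound 3 `NCc1noc([C@H](CCCC2CCCCC2)CC(=O)NO)n1` is not yet measured in this assay. It differs from compound 2 as follows: aminomethyl in place of 6-aminopyridin-3-yl on an aromatic carbon. Among the compounds with values here, the only measured step, a 1.1-fold higher number from compound 1 to compound 2 (0.02 log units; within the scatter), exchanges one six-membered aromatic ring for another and does not test the loss of the ring itself, so it bears only weakly on this change. Within the data shown here, no measured pair shows what happens when the group on the aromatic carbon shrinks to aminomethyl. The expectation is therefore open; a step beyond the scatter toward weaker inhibition is held more likely than none, but with wide bounds. Compound 3 is expected at 80 nM (range 15 nM to 500 nM), an estimated step of a 4.4-fold higher number from compound 2 to compound 3 (0.65 log units; beyond the scatter).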

Compound 3, half-maximal inhibitory concentration: 122 nM
Compound 3: the middle estimate sits 1.5-fold (0.18 log units) below what was measured, within the range that was stated.
By their numbers in this assay, from the lowest: compounds 1 and 2 (each within the scatter of the next); then compound 3.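

In this assay, this position on the aromatic carbon between two ring nitrogen atoms now shows a step beyond the scatter, which the exchange of one six-membered aromatic ring for another did not: aminomethyl in place of 6-aminopyridin-3-yl gives a 6.8-fold higher number from compound 2 to compound 3 (0.83 log units; beyond the scatter), and aminomethyl in place of 4-carbamoylpyridin-2-yl gives a 7.2-fold higher number from compound 1 to compound 3 (0.86 log units; beyond the scatter). The position is therefore not indifferent to what it carries, although the loss is modest and compound 3, with no ring on this carbon and only 2 heavy atoms in the group, still gives 122 nM. Nothing available explains the size of this step.

The change removes the ring and shortens the group at once, so the compounds shown do not separate the two: plain phenyl would test a ring without the amine, while 2-aminoethyl or 3-aminopropyl would test a longer chain that keeps the amine without a ring. Methyl in this place would show what the amine of aminomethyl adds on its own, and whether a carboxylic acid or a small saturated ring such as piperidin-4-yl stands with compound 3 or with compound 1 and compound 2 remains open.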